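The compounds below may be only part of what the source reports. "The series", "measured", "known", "first", "only" and "open" are said of these compounds alone.

Compound 1 `CC1(c2ccccc2)CC(=O)N(CC(=O)N2CCN(c3ccccc3)CC2)C1=O`: 300 mg/kg. Compound 2 `CC1(c2ccccc2)CC(=O)N(CC(=O)N2CCN(c3ccc(Cl)cc3)CC2)C1=O`: "not active" (no number reported). Compound 3 `Cc1cccc(N2CCN(C(=O)CN3C(=O)CC(C)(c4ccccc4)C3=O)CC2)c1`: 100 mg/kg.

All three were tested in a functional assay on the whole organism (strain CD-1) with Mus musculus as the target, in the maximal electroshock model, with a stated time of 0.5 h; a lower number here means that less compound is needed, a higher number that more compound is needed for the effect. Compound 3 holds the lowest of the two numbers; its nearest neighbour is compound 1, and the change is a 3.0-fold lower number from compound 1 to compound 3 (0.48 log units; beyond the scatter), a methyl in place of hydrogen on an aromatic carbon. Compound 2 carries no number, only the report that it was not active in this assay. Compound 4 `CC1(c2ccccc2)CC(=O)N(CC(=O)N2CCN(c3cccc(Cl)c3Cl)CC2)C1=O` is still unmeasured and differs from compound 3 in one place: 2,3-dichlorophenyl in place of 3-methylphenyl on an amine nitrogen in a ring. Among the measured compounds shown here, no measured step concerns this exchange directly; the only recorded step, from compound 1 to compound 3, involves a methyl and was modest. What compound 1 and compound 2 show is that a different exchange on the same ring went from a number to no activity: compound 1 gives 300 mg/kg, while compound 2 gives "not active" (no number reported). For compound 4 this suggests an expected 3.0-fold higher number from compound 3 to compound 4 (0.48 log units; beyond the scatter), with a real chance that only a limit is reported. Compound 4 is therefore estimated at 300 mg/kg, expected to lie between 100 mg/kg and 900 mg/kg.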

Compound 4, minimum effective dose: "not active" (no number reported)
Compound 4: no number reported; the estimate stays without a comparison.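

Among the compounds shown here, compound 4 carries no number, only the report that it was not active, so no step from compound 3 to compound 4 can be read. Nothing measured here explains this result. The compounds shown leave open whether any chlorine-bearing phenyl group on this shared core can give a number.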